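Amide replacement on a catechol ether core

The source may report more compounds than this note shows. Statements on the series, on what has been measured and on what is new or still open speak of the compounds shown alone.

Compound 1 `COc1ccc(C(=O)Nc2ccccc2Br)cc1OC1CCCC1`: 130 nM
Compound 2 `COc1ccc(C(=O)Nc2c(Cl)cccc2Cl)cc1OC1CC2CCC1C2`: 10 nM
Compound 3 `COc1ccc(C(=O)Nc2ccccc2Cl)cc1OC(=O)C(C)(C)C`: > 1000000 nM

In an assay on isolated protein for inhibition of phosphodiesterase 4A (Sus scrofa) (on this read-out higher numbers stand for weaker inhibition and lower numbers for stronger inhibition), compound 1 gives 130 nM, the highest of the two numbers shown, with compound 2 at 10 nM, a step beyond the scatter. For compound 3 this assay reports only a limit, > 1000000 nM. Compound 4 `COc1ccc(C(=O)NC2(C)C=C(C)ON2)cc1OC1CCCC1` keeps the cyclopentyloxy core of compound 1 and changes the amide side: a group of 7 heavy atoms (5 carbon, 1 nitrogen, 1 oxygen; one five-membered non-aromatic ring with 2 hetero atoms) in place of a group of 7 heavy atoms (6 carbon, 1 bromine; one six-membered aromatic ring of carbon only), on an amide-type nitrogen. Going by the values given here, no measured step of this kind is available, so the expectation rests on compound 1 alone; a weakening beyond the scatter is expected, since every potent compound here carries a halogenated aryl amide. Compound 4 is therefore estimated at 1500 nM (range 150 nM to 15000 nM), an expected step of a 12-fold higher number from compound 1 to compound 4 (1.06 log units; beyond the scatter).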

Compound 4, half-maximal inhibitory concentration: 450 nM
Compound 4: the middle estimate sits 3.3-fold (0.52 log units) above what was measured; measured number inside the range.
By their numbers in this assay, from the lowest: compound 2; then compound 1; then compound 4. At a limit, above all of these: compound 3.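

In this assay, a halogenated aryl group on the amide-type nitrogen proves not to be essential: replacing 2-bromophenyl with the non-aromatic five-membered ring with 2 hetero atoms gives a 3.5-fold higher number from compound 1 to compound 4 (0.54 log units; beyond the scatter) and leaves compound 4 as the only non-aryl amide shown, with a modest loss. Nothing measured here accounts for this step.

The compounds shown leave open whether an unsubstituted phenyl or a pyridine on that nitrogen would fall nearer compound 1 or compound 4. They also leave open whether the same ring would behave alike on the core of compound 2.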